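Compound 3 to Compound 4: Changing the Halogenated Phenyl

The source may hold more compounds than are shown below. What is called first, only, known or untested is meant among the compounds shown, and "the series" means these compounds.

Compound 3 `O=C(/C=C\c1ccccc1Cl)N1N=C(c2ccncc2)OC1c1c[nH]c2ccccc12` was tested in an ADME assay on A549 cells (Homo sapiens) for cytotoxicity, read by MTT assay, with a stated time of 48 h; a lower number here means a stronger inhibitor of growth, a higher number a weaker inhibitor of growth. In this assay compound 3 gives only a limit, > 30 ug/mL. Compound 1 `Cc1ccc(/C=C\C(=O)N2N=C(c3ccncc3)OC2c2c[nH]c3ccccc23)cc1` gives likewise a limit, > 30 ug/mL. Compound 2 `O=C(/C=C\c1ccc(F)cc1)N1N=C(c2ccncc2)OC1c1c[nH]c2ccccc12` also gives a limit, > 30 ug/mL. Thus (the limit of > 30 ug/mL in this assay, at which 3 of the 3 values shown sit), and the steps a step that the two limits leave unreadable from compound 1 to compound 3 and a step that the two limits leave unreadable from compound 2 to compound 3 cannot be read in size or direction. Compound 4 `O=C(/C=C\c1cccc(Br)c1)N1N=C(c2ccncc2)OC1c1c[nH]c2ccccc12` has not yet been measured. It differs from compound 3 by 3-bromophenyl in place of 2-chlorophenyl on a double-bonded chain carbon bound to a double-bonded chain carbon. Every measured step touching this phenyl group is unreadable, so no size or direction can be drawn from them. The step that the limit leaves unreadable from compound 3 to compound 4 is accordingly expected to stay within the scatter. Compound 4 is expected to give about 45 ug/mL in this assay, with a likely range from 15 ug/mL to 120 ug/mL.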

Compound 4, concentration for 50% growth inhibition: > 30 ug/mL
Compound 4: no number, only a limit; the forecaster's own chance of this, stated with the estimate: 85%; the middle value is on the limit's open side.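

Like compound 1, compound 2 and compound 3, compound 4 gives only a limit in this assay, so no step between compound 4 and these compounds can be read: the limit of > 30 ug/mL in this assay, at which 4 of the 4 values shown sit. The compounds shown leave open how strongly any of them inhibits growth, and whether changing the substituted phenyl group alters that at all.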